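Benzamide aryl variation on the shared core: added methoxy groups

This account rests on a few compounds, and the source may have more. Where it says the series, first, only, none or still open, it means among the compounds named here.

Measured so far:
compound 1 `CNc1nc(Nc2ccc(C)c(N)c2)ncc1C(=O)Nc1cc(NC(=O)c2cccc(C(F)(F)F)c2)ccc1C` gives 14 nM in a functional assay on K562 cells (Homo sapiens) for antiproliferative activity, read by CellTiter-Glo and CCK-8 assay, with a stated time of 72 h; on this read-out higher numbers stand for weaker inhibition of growth and lower numbers for stronger inhibition of growth
compound 2 `CNc1nc(Nc2ccc(C)c(N)c2)ncc1C(=O)Nc1cc(NC(=O)c2ccc(OC)cc2)ccc1C` gives 610 nM in this assay

Among the compounds with values here, compound 2 stands at the higher of the two numbers; the single measured step, a 44-fold higher number from compound 1 to compound 2 (1.64 log units; beyond the scatter), is large. Compound 3 `CNc1nc(Nc2ccc(C)c(N)c2)ncc1C(=O)Nc1cc(NC(=O)c2cc(OC)c(OC)c(OC)c2)ccc1C` differs from compound 2 by 3,4,5-trimethoxyphenyl in place of 4-methoxyphenyl on a carbonyl carbon. Within the data shown here, no measured step covers adding methoxy groups at this carbonyl carbon; the one step known concerns a different exchange there and gives no direction for this change. For compound 3 the expected step is a 1.5-fold higher number from compound 2 to compound 3 (0.17 log units; within the scatter), not clearly beyond the scatter. Compound 3 is estimated at 900 nM, between 200 nM and 4000 nM.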

Compound 3, concentration for 50% growth inhibition: 250 nM
The estimate for compound 3 lay 3.6-fold (0.56 log units) above the measured number; the measured number falls inside the stated range.
By their numbers in this assay, from the lowest: compound 1; then compound 3; then compound 2.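

Replacing 4-methoxyphenyl with 3,4,5-trimethoxyphenyl on this carbonyl carbon gives a 2.4-fold lower number from compound 2 to compound 3 (0.39 log units; beyond the scatter) in this assay and so recovers a modest part of the large loss seen with compound 2. The recovery remains limited, with an 18-fold higher number from compound 1 to compound 3 (1.25 log units; beyond the scatter) and 3-(trifluoromethyl)phenyl still well ahead. Nothing at hand accounts for the gain with the added methoxy groups.

Open, as far as these compounds go, is whether all three methoxy groups are needed for this step. Also open, from the compounds shown here alone, is how a dimethylamino group or a carboxylic acid on this aryl ring would compare with trifluoromethyl.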